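This account rests on a few compounds, and the source may have more. Where it says the series, first, only, none or still open, it means among the compounds named here.

For the measured compounds named here, in a functional assay on HCT-116 cells (Homo sapiens) for antiproliferative activity, read by MTT assay, with a stated time of 72 h (on this read-out lower numbers stand for stronger inhibition and higher numbers for weaker inhibition), compound 1 `COc1ccc(/C=C2/CN(C)/C(=N/c3ccc(C(C)(C)C)cc3)S2)cc1` gives 25900 nM, the higher of the two numbers measured so far. Compound 2 `COc1ccc(/C=C2\S/C(=N\c3ccc(Cl)cc3)N(C)C2=O)cc1` gives 10400 nM, and the gap between the two lies beyond the usual scatter of repeated measurements. Compound 3 `COc1ccc(/C=C2/CN(C)/C(=N/c3ccc(Cl)cc3)S2)cc1` has not yet been measured. It keeps the core of compound 1 and changes one group, with chloro in place of tert-butyl on an aromatic carbon, para to a large group (chloro in place of tert-butyl on an aromatic carbon). Going by the values given here, no two measured compounds differ in only one place, so the data offer no direct measure of this change. A modest move toward a lower number is expected in this assay, of a size that may stay within the scatter. Among the compounds with values here, the only lower reference is compound 2 at 10400 nM, which suggests the direction but does not settle the size. The estimated change is a 1.9-fold lower number from compound 1 to compound 3 (0.27 log units; within the scatter). For compound 3, the expected value is 14000 nM, with an estimated range of 6000 nM to 30000 nM.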

Compound 3, half-maximal inhibitory concentration: 9800 nM
Compound 3: the middle estimate sits 1.4-fold (0.15 log units) above what was measured; measured number inside the range.
By their numbers in this assay, from the lowest: compounds 3 and 2 (each within the scatter of the next); then compound 1.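

In this assay, this is the first direct reading of a single change among these compounds: chloro in place of tert-butyl on an aromatic carbon, para to a large group, gives a 2.6-fold lower number from compound 1 to compound 3 (0.42 log units; beyond the scatter). The earlier compounds shown here could only hint at this, whereas the pair now shows that, with the rest of the core of compound 1 held fixed, the group at this position matters to the antiproliferative read-out, and that the step, though modest, lies beyond the scatter. No measurement shown here bears on the reason for the step.

Going by these compounds, with only tert-butyl and chloro to compare at this position, it remains open whether the number follows the heavy-atom count of the group or the identity of chloro itself, a question that a methyl, a fluoro, an amine or a carboxylic acid in the same place could help to settle. It is also open whether the same exchange would give a step of similar size on the core of compound 2, which carries chloro and has no tert-butyl partner among these compounds.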